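Swapping bromo for nitro on a shared triazolothiadiazine-free core: compound 4

This account rests on a few compounds, and the source may have more. Where it says the series, first, only, none or still open, it means among the compounds named here.

Measured so far in a functional assay on HCT-116 cells (Homo sapiens) for inhibition, read by sulforhodamine B assay, with a stated time of 72 h; a lower number here means a stronger inhibitor, a higher number a weaker inhibitor:
- compound 1, `CC(c1ccc(-c2ccccc2)c(F)c1)c1nnc2n1N=C(c1ccccc1)CS2`, gives 9700 nM
- compound 2, `CC(C)Cc1ccc(C(C)c2nnc3n2N=C(c2ccc(Br)cc2)CS3)cc1`, gives 7100 nM
- compound 3, `CC(c1ccc(-c2ccccc2)c(F)c1)c1nnc2n1N=C(c1ccc([N+](=O)[O-])cc1)CS2`, gives 7100 nM

All three compounds share one core and differ only in the groups hung on it. Compound 2 is level with compound 3 at the digits shown, and its gap to compound 1 is within the usual scatter of this assay, so the three numbers cannot be told apart with confidence.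

Compound 4, `CC(C)Cc1ccc(C(C)c2nnc3n2N=C(c2ccc([N+](=O)[O-])cc2)CS3)cc1`, is made from compound 2 by one change: nitro in place of bromo on an aromatic carbon. Within the data shown here, no measured pair shows exactly this swap. The nearest guide is the change from compound 1 to compound 3, where a nitro group also enters the same position of that ring, there in place of hydrogen, and the result was a 1.4-fold lower number from compound 1 to compound 3 (0.14 log units; within the scatter). That step stayed within the scatter, so a nitro group at this place has not yet moved the number in a way that can be trusted.

The expectation for compound 4 is therefore no step beyond the scatter, a 1.1-fold lower number from compound 2 to compound 4 (0.04 log units; within the scatter). Compound 4 is estimated at 6500 nM, within a range from 3000 nM to 14000 nM.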

Compound 4, half-maximal inhibitory concentration: "not active" (no number reported)
The entry for compound 4 holds no number; no gap can be computed for the estimate.
By their numbers in this assay, from the lowest: compounds 2, 3 and 1 (each within the scatter of the next).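

In this assay, among these compounds, compound 4 is reported only as "not active", without a number, so no step from compound 2 to compound 4 can be read. No supporting data bear on this result. The compounds shown leave open how much replacing bromo with nitro separates compound 4 from compound 2.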